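Amide aryl swap on the pyrazole-bearing core

A few compounds are considered here, and "the series" means these few. Any claim that something is new, unique, unknown or untested is made for them only; others in the source may bear on it.

Measured so far:
compound 1 `Cc1noc(C)c1-c1cnc(N)c(Oc2ccc(C(=O)Nc3ccc(Cl)cc3)cc2)n1`, 14400 nM
compound 2 `Cc1noc(C)c1-c1cnc(N)c(Oc2ccc(C(=O)Nc3ccc(Cl)cn3)cc2)n1`, 35600 nM
compound 3 `Cn1cc(-c2cnc(N)c(Oc3ccc(C(=O)Nc4ccc(Cl)cc4)cc3)n2)cn1`, 11900 nM

Read-out is a functional assay on HepG2 cells (Homo sapiens) for inhibition, read by MTT assay, with a stated time of 72 h; a lower number here means a stronger inhibitor, a higher number a weaker inhibitor. Compound 3 gives the lowest number of the three; compound 1 sits within the scatter of it, while compound 2 stands beyond the scatter, at a higher number. The pyrazole in place of the isoxazole, a 1.2-fold lower number from compound 1 to compound 3 (0.08 log units; within the scatter), made no real difference.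

Compound 4 `Cn1cc(-c2cnc(N)c(Oc3ccc(C(=O)Nc4cc(Cl)ccn4)cc3)n2)cn1` is the next compound. The change from compound 3 is 4-chloropyridin-2-yl in place of 4-chlorophenyl on an amide-type nitrogen. For the measured compounds named here, one measured step bears on this: the change of the amide aryl on the isoxazole-bearing core, a 2.5-fold higher number from compound 1 to compound 2 (0.39 log units; beyond the scatter), which carried the pyridine nitrogen at a different place but made the same kind of swap of a chlorophenyl for a chloropyridinyl. That step was modest and toward a weaker inhibitor. A similar modest rise in this assay is therefore expected for compound 4, a 2.3-fold higher number from compound 3 to compound 4 (0.36 log units; beyond the scatter), though the isomer differs and the core differs, so the expectation is loose.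

Estimated for compound 4: 27000 nM, with a range of 12000 nM to 60000 nM.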

Compound 4, half-maximal inhibitory concentration: > 100000 nM
Compound 4 ended at the assay's limit (the forecaster's own chance of this, stated with the estimate: 10%); middle value at least 3.7-fold (0.56 log units) from the limit.
By their numbers in this assay, from the lowest: compounds 3 and 1 (each within the scatter of the next); then compound 2. At a limit, above all of these: compound 4.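

In this assay, 4-chloropyridin-2-yl in place of 4-chlorophenyl on the amide-type nitrogen gives an at least 8.4-fold higher number from compound 3 to compound 4 (0.92 log units; beyond the scatter), so a chloropyridinyl swap here can cost far more than the earlier swap to 5-chloropyridin-2-yl, a 2.5-fold higher number from compound 1 to compound 2 (0.39 log units; beyond the scatter). Compound 4 reads > 100000 nM, which is a limit of the assay and not a number. From the compounds shown here alone, the step is therefore only a floor, and its true size stays unknown: the limit of > 100000 nM in this assay, at which 1 of the 4 values shown sits.

Still open is whether the larger rise follows the 4-chloropyridin-2-yl group itself or its pairing with the 1-methyl-1H-pyrazol-4-yl core, since the compounds shown never place one chloropyridinyl isomer on both cores. Also open, going by these compounds, is how a methoxy or a fluorine in place of the chlorine on the pyridine ring would read.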